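From ethoxy to propoxy: what to expect

The compounds below may be only part of what the source reports. "The series", "measured", "known", "first", "only" and "open" are said of these compounds alone.

Measured compounds:
compound 1 `CCOc1ccc(/C=C/c2cc(OC)c(OC)c(OC)c2)cc1`: 1.49 uM
compound 2 `CCOc1ccc(/C=C\c2cc(OC)c(OC)c(OC)c2)cc1`: 1.8 uM
compound 3 `COc1ccc(C(O)c2cc(OC)c(OC)c(OC)c2)cc1`: 1.2 uM

In a functional assay on HT-29 cells (Homo sapiens) for cytotoxicity (a higher number here means that more compound is needed for the effect, a lower number that less compound is needed), compound 1 gives 1.49 uM. That value lies within the usual scatter of those of compound 2 and compound 3, so these three numbers cannot be ranked.

Compound 4 `CCCOc1ccc(/C=C/c2cc(OC)c(OC)c(OC)c2)cc1` has not yet been measured. It keeps the core of compound 1 and turns ethoxy into propoxy: methyl in place of hydrogen on a saturated chain carbon, two bonds along the chain from an oxygen on an aromatic ring.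

Within the data shown here, the only measured step between compounds differing in one place is a 1.2-fold higher number from compound 1 to compound 2 (0.08 log units; within the scatter). Among the measured compounds shown here, it rests on the fact that compounds 1 and 2 differ only in the configuration as drawn and leaves the chain untouched, so no measured step tests this change directly. It offers only a loose guide to size. Starting from compound 1 at 1.49 uM, no step beyond the scatter is expected in this assay, and no direction can be given. The expected step is a 1.1-fold higher number from compound 1 to compound 4 (0.03 log units; within the scatter). For compound 4 the estimate is 1.6 uM, with an expected range of 0.6 uM to 4 uM.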

Compound 4, concentration for half-maximal effect: > 25 uM
Compound 4: no number, only a limit; the forecaster's own chance of this, stated with the estimate: 2%; at least 15-fold (1.19 log units) between middle value and limit.
By their numbers in this assay, from the lowest: compounds 3, 1 and 2 (each within the scatter of the next). At a limit, above all of these: compound 4.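

In this assay, going from ethoxy to propoxy on the shared core gives a large step: an at least 16-fold higher number from compound 1 to compound 4 (1.22 log units; beyond the scatter). Compound 4 gives > 25 uM, which is a limit of the assay and not a number. Among these compounds, the earlier compounds could not show that this chain matters, as their values all lie within the scatter and their only measured step changes the drawn configuration of the double bond while leaving the chain untouched.

How far the true value of compound 4 lies past that limit stays open, and these compounds give no cause for the step. From the compounds shown here alone, it is also open whether a butoxy or isopropoxy group in place of propoxy would give a number that can be read in this assay.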